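Replacing the fused bicyclic amide group with a hydroxyphenyl

The source may hold more compounds than are shown below. What is called first, only, known or untested is meant among the compounds shown, and "the series" means these compounds.

Measured so far:
compound 1, `COc1ccc(NC(=O)[C@H]2CCCN2C(=O)C2(c3ccc(Cl)cc3)CCCC2)cc1`, gives 7.94 nM in an assay on isolated protein for inhibition of histone acetyltransferase p300 (Homo sapiens), with a stated time of 60 min; a lower number here means a stronger inhibitor, a higher number a weaker inhibitor
compound 2, `O=C1Cc2cc(NC(=O)[C@H]3CCCN3C(=O)C3(c4cccc(Cl)c4)CCCC3)ccc2N1`, gives 0.794 nM in this assay
compound 3, `O=C(Nc1ccc2[nH]ncc2n1)[C@H]1CCCN1C(=O)C1(c2ccc(Cl)cc2)CC(F)(F)C1`, gives 0.316 nM in this assay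

Among these three numbers compound 2 stands second highest. Its nearest neighbour is compound 3, whose number is lower by a margin beyond the usual scatter; its furthest is compound 1, whose number is higher by a wider margin, also beyond the scatter.

Compound 4, `O=C(Nc1ccc(O)cc1)[C@H]1CCCN1C(=O)C1(c2cccc(Cl)c2)CCCC1`, has not yet been measured. It differs from compound 2 in one place: a group of 7 heavy atoms (6 carbon, 1 oxygen; one six-membered aromatic ring of carbon only) in place of a group of 10 heavy atoms (8 carbon, 1 nitrogen, 1 oxygen; one five-membered non-aromatic ring with 1 hetero atom, one six-membered aromatic ring of carbon only), on an amide-type nitrogen

Going by the values given here, no measured pair shows this change on its own. Compound 1 also carries a plain six-membered aromatic ring of carbon only on that amide nitrogen, but it differs from compound 2 in more than one place, so its value is only a rough pointer. A step upward in this assay is expected, beyond the scatter, yet smaller than the gap from compound 2 to compound 1. Compound 4 is therefore estimated at 4 nM, within a range of 1.5 nM to 12 nM. That estimate means an expected step of a 5.0-fold higher number from compound 2 to compound 4 (0.70 log units; beyond the scatter).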

Compound 4, half-maximal inhibitory concentration: 0.631 nM
Beside the measured number, compound 4's estimate is 6.3-fold (0.80 log units) above it, and the stated range ends above it.
By their numbers in this assay, from the lowest: compounds 3, 4 and 2 (each within the scatter of the next, the first and the last beyond it); then compound 1.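

In this assay, putting 4-hydroxyphenyl on the amide-type nitrogen in place of the larger group with two rings gives a 1.3-fold lower number from compound 2 to compound 4 (0.10 log units; within the scatter), a step within the usual scatter, so this assay cannot tell the two groups apart. In this pair, then, the five-membered non-aromatic ring is not needed to keep the number in the range of compound 2, and a single six-membered aromatic ring carrying a hydroxyl does as well; both groups count one hydrogen-bond donor and one acceptor. Nothing measured here accounts for this match.

As far as these compounds go, it remains open whether the hydroxyl itself matters, which a plain phenyl or a 4-aminophenyl on the same nitrogen, with the rest of compound 4 kept, would test. From the compounds shown here alone, whether the match holds on another core, such as that of compound 3, is also open.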